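A few compounds are considered here, and "the series" means these few. Any claim that something is new, unique, unknown or untested is made for them only; others in the source may bear on it.

Working notes on the series.

Two members have been run so far. Compound 1 `O=C(Nc1cccc(Oc2ccccn2)c1)C1CCCN(C(=O)c2cc(C(F)(F)F)cc(C(F)(F)F)c2)C1` gives 0% in an ADME assay on PC-3 cells (Homo sapiens) for cytotoxicity, read by WST assay, tested at 100 uM; a lower number here means less inhibition, a higher number more inhibition at the concentration tested (going by the name of the read-out). Compound 2 `N#Cc1cccc(C(=O)N2CCCC(C(=O)Nc3ccc(Cl)cc3)C2)c1` gives 0% in the same assay. On the numbers shown, compound 2 stands level with compound 1 at the digits reported; the two values lie within the usual scatter of each other, so no order between them can be read.

The next member, compound 3 `Cc1nc(-c2cccc(C(=O)N3CCCC(C(=O)Nc4ccc(Cl)cc4)C3)c2)cs1`, has not yet been measured in this assay. Compared with compound 2, the change is 2-methyl-1,3-thiazol-4-yl in place of cyano on an aromatic carbon. Among the compounds with values here, no step between two measured compounds is available as a guide, since compound 1 and compound 2 differ in more than one place and both read the same.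

Given that compound 2 shows 0% and compound 1 likewise shows 0%, the step from compound 2 to compound 3 is expected to be a number 5 percentage points higher from compound 2 to compound 3 (within the scatter), that is, no change beyond the scatter in either direction. Compound 3 is therefore estimated to give 5%, within a range of 0% to 25%.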

Compound 3, a percentage reported as inhibition, at one concentration (the size of the read-out at that concentration, not a potency): 1%
For compound 3 the middle estimate is 4 percentage points above the measured one; measured number inside the range.
By their numbers in this assay, from the lowest: compounds 1, 2 and 3 (each within the scatter of the next).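

At this position, on an aromatic carbon of a six-membered aromatic ring of carbon only, meta to a large group, 2-methyl-1,3-thiazol-4-yl in place of cyano gives a number 1 percentage points higher from compound 2 to compound 3 (within the scatter) in this assay for this single change. Within the data shown here, this is the first comparison between two measured compounds that differ in one place, and it shows that this position accepts a five-membered aromatic ring with a methyl group in place of the nitrile with no shift beyond the scatter in this read-out. No accompanying measurement bears on this result, so no cause can be assigned to it.

The compounds shown establish only one exchange at this position, between two groups that leave the reading within the scatter, so they do not show whether any group placed here can move it beyond the scatter. Going by these compounds, whether a basic amine such as a dimethylaminomethyl group, or a carboxylic acid, on the same aromatic carbon would read differently remains open, as does the effect of a single change anywhere else on the shared core.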